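Working notes: from compound 2 to compound 4

The compounds below may be only part of what the source reports. "The series", "measured", "known", "first", "only" and "open" are said of these compounds alone.

In a functional assay on RPMI-8226 cells (Homo sapiens) for inhibition, read by sulforhodamine B assay, with a stated time of 48 h (a lower number here means a stronger inhibitor of growth, a higher number a weaker inhibitor of growth), compound 1 (`O=C(Cc1csc2nc(-c3ccc(Br)cc3)cn12)N/N=C/c1ccccc1O`) gives 2820 nM while compound 2 (`O=C(Cc1csc2nc(-c3ccc(Br)cc3)cn12)N/N=C/c1ccc(O)cc1`) gives 4270 nM and compound 3 (`COc1cccc(OC)c1/C=N/NC(=O)Cc1csc2nc(-c3ccc(Br)cc3)cn12`) gives 10200 nM on the same scale. Where compound 2 stands is set by two steps: a 1.5-fold higher number from compound 1 to compound 2 (0.18 log units; within the scatter) and a 2.4-fold higher number from compound 2 to compound 3 (0.38 log units; beyond the scatter) in the same series. Compound 4 (`O=C(Cc1csc2nc(-c3ccc(Br)cc3)cn12)N/N=C/c1ccc(Cl)cc1Cl`) carries 2,4-dichlorophenyl in place of 4-hydroxyphenyl on a carbon with a double bond to nitrogen. Among the measured compounds shown here, the measured changes at this place are small, the largest being a 3.6-fold higher number from compound 1 to compound 3 (0.56 log units; beyond the scatter) among the three, and no measured compound carries chlorine, so no direction can be read from them. No step beyond the scatter is expected in this assay here. The expected step is a 1.2-fold lower number from compound 2 to compound 4 (0.09 log units; within the scatter) on this estimate. Compound 4 is estimated at 3500 nM with an expected range (1300 nM to 10000 nM).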

Compound 4, concentration for 50% growth inhibition: 79400 nM
For compound 4 the middle estimate is 23-fold (1.36 log units) below the measured one, and the stated range ends below it.
By their numbers in this assay, from the lowest: compounds 1 and 2 (each within the scatter of the next); then compound 3; then compound 4.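

In this assay the group on the carbon with a double bond to nitrogen matters more than the three earlier compounds showed, with 2,4-dichlorophenyl giving a 19-fold higher number from compound 2 to compound 4 (1.27 log units; beyond the scatter) and a 28-fold higher number from compound 1 to compound 4 (1.45 log units; beyond the scatter) as steps larger than any seen before. The change from the dimethoxy compound gives a 7.8-fold higher number from compound 3 to compound 4 (0.89 log units; beyond the scatter) as well, so compound 4 has the highest number of the four and a hydroxyl is not needed to separate it from compound 3. Nothing available accounts for this loss of growth inhibition.

The compounds shown leave open whether the loss follows the chlorine atoms or the particular pattern of 2,4-dichlorophenyl. An amine or a carboxylic acid on this phenyl ring would extend the comparison beyond hydroxyl, methoxy and chlorine.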